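The source may hold more compounds than are shown below. What is called first, only, known or untested is meant among the compounds shown, and "the series" means these compounds.

Measured so far in an assay on isolated protein for binding affinity to histamine H2 receptor (Homo sapiens); on this read-out lower numbers stand for stronger inhibition and higher numbers for weaker inhibition:
- compound 1, `O=C(c1ccc(OCCCN2CC[C@H](NS(=O)(=O)c3ccc(Br)cc3)C2)cc1)C1CC1`: 290 nM
- compound 2, `N#Cc1ccc(S(=O)(=O)N[C@H]2CCN(CCCOc3ccc(C(=O)C4CC4)cc3)C2)cc1`: 1600 nM
- compound 3, `O=C(c1ccc(OCCCN2CC[C@H](NS(=O)(=O)c3ccc(Cl)cc3)C2)cc1)C1CC1`: 290 nM

Compound 3 stands level with compound 1 at the digits shown, the two together the lowest numbers of the three; compound 2 sits furthest, a 5.5-fold lower number from compound 2 to compound 3 (0.74 log units; beyond the scatter). Compound 4, `CC(C)(C)c1ccc(S(=O)(=O)N[C@H]2CCN(CCCOc3ccc(C(=O)C4CC4)cc3)C2)cc1`, is not yet measured. It differs from compound 3 by tert-butyl in place of chloro on an aromatic carbon. Within the data shown here, no measured step touches tert-butyl. The nearest steps are no change at the digits printed from compound 1 to compound 3 (within the scatter), a swap of one halogen for another, and a 5.5-fold higher number from compound 1 to compound 2 (0.74 log units; beyond the scatter), where cyano entered. The step to compound 4 is therefore expected to fall between these: no change beyond the scatter or a modest rise. For compound 4 the estimate in this assay is 450 nM, range 130 nM to 1500 nM, that is an expected step of a 1.6-fold higher number from compound 3 to compound 4 (0.19 log units; within the scatter).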

Compound 4, inhibition constant: 730 nM
Estimate against measurement, compound 4: 1.6-fold (0.21 log units) below; low and high end bracket the measured number.
By their numbers in this assay, from the lowest: compounds 1 and 3 (each within the scatter of the next); then compound 4; then compound 2.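

In this assay this position, para to a large group, does not keep the halogen level once tert-butyl enters, with four heavy atoms for one: a 2.5-fold higher number from compound 3 to compound 4 (0.40 log units; beyond the scatter) and a 2.5-fold higher number from compound 1 to compound 4 (0.40 log units; beyond the scatter). The bulkier group still stands on the lower side of the nitrile, with a 2.2-fold lower number from compound 2 to compound 4 (0.34 log units; beyond the scatter). The data in hand offer no explanation for this order. Open, from the compounds shown here alone, is how fluoro, methyl or methoxy would fall at this position. Also open, going by these compounds, is whether an amine or a carboxylic acid here would be tolerated as tert-butyl is.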